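The source may hold more compounds than are shown below. What is called first, only, known or untested is meant among the compounds shown, and "the series" means these compounds.

Compound 1 `C=CC1=C(C(=O)O)C(c2ccc(F)cc2)OC1` gives > 100000 nM in a functional assay on QGY7701 cells (Homo sapiens) for cytotoxicity, read by MTT assay, with a stated time of 24 h (on this read-out lower numbers stand for stronger inhibition and higher numbers for weaker inhibition), which is a limit of the assay rather than a number.
Compound 2 `C=CC1=C(C(=O)NCCC)C(c2ccc(Cl)c(Cl)c2)OC1` gives 31300 nM in this assay.
Compound 3 `C=CC1=C(C(=O)O)C(c2ccc(OC)cc2)OC1` gives > 100000 nM in this assay, again a limit of the assay.

Compound 1 thus stands at the limit, where two of the three values shown sit (the limit of > 100000 nM in this assay, at which 2 of the 3 values shown sit). Among the compounds with values here, the only computed step, a step that the two limits leave unreadable from compound 1 to compound 3, runs from one limit to another and cannot be sized. Compound 4 `C=CC1=C(C(=O)Nc2ccccc2)C(c2ccc(F)cc2)OC1` differs from compound 1 by anilino in place of hydroxy on a carbonyl carbon. Within the data shown here, no measured step touches this change; compound 2, which carries an amide, is the one value shown that is a number, and that is all it shows. The expected step of an at least 3.3-fold lower number from compound 1 to compound 4 (0.52 log units; beyond the scatter) is therefore uncertain, leaning toward a number rather than a limit. Compound 4 is estimated at 30000 nM, between 8000 nM and 100000 nM.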

Compound 4, half-maximal inhibitory concentration: 46700 nM
For compound 4 the middle estimate is 1.6-fold (0.19 log units) below the measured one, and the stated range covers the measured number.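

Putting anilino in place of hydroxy on the carbonyl carbon brings an at least 2.1-fold lower number from compound 1 to compound 4 (0.33 log units; beyond the scatter) in this assay, so a change at this place can lift the read-out off its limit. Compound 1 holds a limit and not a number, so the true size of this step may be larger. Both carboxylic acids shown remain at that limit: the limit of > 100000 nM in this assay, at which 2 of the 4 values shown sit.

Going by these compounds, whether a methyl ester or a benzylamino group on the same carbonyl carbon would also give a readable number stays open. So does the effect of a methoxy group on the anilino ring.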